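From Two Cyclohexyl Groups to One Benzyl

The source may report more compounds than this note shows. Statements on the series, on what has been measured and on what is new or still open speak of the compounds shown alone.

In a functional assay on LOX IMVI cells (Homo sapiens) for inhibition, read by sulforhodamine B assay, with a stated time of 48 h, tested at 10 uM (a lower number here means less inhibition, a higher number more inhibition at the concentration tested (going by the name of the read-out)), compound 3 `c1cn2cc(-c3ccc4c(c3)ncn4C3CCCCC3)nc(-c3ccc4ncn(C5CCCCC5)c4c3)c2n1` gives 25.9%. Among the three measured compounds it stands second: compound 1 `Cc1cccc(-c2cn3ccnc3c(-c3ccc4ncn(Cc5ccccc5)c4c3)n2)c1` gives 14.8%, lower by a margin beyond the scatter, and compound 2 `O=Cc1ccc(-c2cn3ccnc3c(-c3ccc4ncn(Cc5ccccc5)c4c3)n2)cc1` gives 46.9%, higher by a margin beyond the scatter. Among the measured compounds shown here, the only measured step, a number 32.1 percentage points higher from compound 1 to compound 2 (beyond the scatter), swaps a group on an aromatic carbon and so says nothing directly about a swap on an aromatic nitrogen. Compound 4 `c1ccc(Cn2cnc3ccc(-c4nc(-c5ccc6c(c5)ncn6C5CCCCC5)cn5ccnc45)cc32)cc1` differs from compound 3 by benzyl in place of cyclohexyl on an aromatic nitrogen. Compound 1 also carries a benzyl group and sits lower than compound 3, but its other ring substituent differs as well, so that comparison is loose. For compound 4 a step of a number 1.9 percentage points lower from compound 3 to compound 4 (within the scatter) is expected, within the scatter. Compound 4 is therefore estimated at 24%, between 10% and 42%.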

Compound 4, a percentage reported as inhibition, at one concentration (the size of the read-out at that concentration, not a potency): -87%
Beside the measured number, compound 4's estimate is 111 percentage points above it; the measured number lies below the stated range.
By their numbers in this assay, from the lowest: compound 4; then compound 1; then compound 3; then compound 2.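

In this assay this aromatic nitrogen proves far from neutral: benzyl in place of cyclohexyl gives a number 112.9 percentage points lower from compound 3 to compound 4 (beyond the scatter), with no other change between the two structures. Among the compounds shown here, the earlier step lay on an aromatic carbon, so only this pair shows how strongly the reading responds at this position. Nothing measured here explains the size of this step.

As far as these compounds go, whether a methyl group, a phenethyl group or a chain ending in an amine on this nitrogen would read closer to compound 3 or to compound 4 remains open.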